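Fluoro for Hydrogen on a Phenyl Ring: Microsomal Stability

The source may hold more compounds than are shown below. What is called first, only, known or untested is meant among the compounds shown, and "the series" means these compounds.

The measured compounds, with their values in an ADME assay on microsomes from liver (Homo sapiens), read by LC-MS, using NADPH, with a stated time of 30 min, tested at 1 uM; a lower number here means that less of the compound is left, a higher number that more of the compound is left:
compound 1, `C[C@H](Nc1ncnc2[nH]cnc12)c1cc2ccccn2c(=O)c1-c1ccccc1`, gives 100%
compound 2, `C[C@H](Nc1ncnc2[nH]cnc12)c1cc2ccc(F)cn2c(=O)c1-c1ccccc1`, gives 98%
compound 3, `C[C@H](Nc1ncnc(N)c1C#N)c1cc(=O)n2cc(F)ccc2c1-c1cccc(F)c1`, gives 87%

Compounds 1 and 2 share one core and differ in one place, (fluoro in place of hydrogen on an aromatic carbon). The step is a number 2 percentage points lower from compound 1 to compound 2 (within the scatter), so the two values cannot be told apart. Compound 3 carries a different core; how its core differs from that of compound 1 is not broken down here. In this assay compound 3 stands lowest of the three, with compound 2 nearest and compound 1 furthest, both beyond the scatter.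

Compound 4, `C[C@H](Nc1ncnc(N)c1C#N)c1cc(=O)n2cc(F)ccc2c1-c1cc(F)cc(F)c1`, has not yet been measured. It differs from compound 3 in one place, (fluoro in place of hydrogen on an aromatic carbon). This is the same kind of change as that from compound 1 to compound 2, but the place differs: in compound 2 the fluoro enters a six-membered aromatic ring with one nitrogen, part of a fused system of two rings, two atoms from the ring nitrogen, while in compound 4 it enters a six-membered aromatic ring of carbon only, meta to a fluoro group and meta to a large group.

Among the measured compounds shown here, since the one measured step of this kind, a number 2 percentage points lower from compound 1 to compound 2 (within the scatter), lay within the scatter, the step from compound 3 to compound 4 is expected to be small as well, about a number 4 percentage points lower from compound 3 to compound 4 (within the scatter). Compound 4 is therefore estimated at 83% in this assay, with a likely range from 68% to 96%.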

Compound 4, percent of the compound remaining: 91%
For compound 4 the middle estimate is 8 percentage points below the measured one, and the stated range covers the measured number.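

Fluoro in place of hydrogen on an aromatic carbon, here 3-fluorophenyl to 3,5-difluorophenyl, gives in this assay a number 4 percentage points higher from compound 3 to compound 4 (within the scatter). Set side by side, the two steps of this kind in the series cannot be told apart, so on these two cores the change leaves no measurable mark on the percent of compound remaining: the same change on two cores in this assay, a number 2 percentage points lower (within the scatter) from compound 1 to compound 2 and a number 4 percentage points higher (within the scatter) from compound 3 to compound 4, 6 percentage points apart, within the scatter of two such steps This does not show that the change is neutral across the series, since it rests on only two pairs, the fluoro enters a different place in each pair, and neither step gives a measurable effect whose transfer from one core to the other could be followed.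

The compounds shown leave open how a chloro, a methoxy or an amine would read in this assay at the place on the ring of carbon only where the fluoro of compound 4 enters. They also leave open whether the 3-fluorophenyl to 3,5-difluorophenyl change would read the same on the core of compound 1, where the same place could be compared directly across the two cores.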